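Fluoro for ethyl on a fused ring in MCF7

The source may hold more compounds than are shown below. What is called first, only, known or untested is meant among the compounds shown, and "the series" means these compounds.

Compound 1, `CCn1c(=O)/c(=C2\Sc3ccccc3N2C)s/c1=C\c1ccncc1Nc1ccccc1Cl`: 750 nM
Compound 2, `CCc1ccc2c(c1)S/C(=c1/s/c(=C\c3ccncc3Nc3ccccc3F)n(CC)c1=O)N2C`: 1200 nM

Of the compounds shown here, two have been measured in a functional assay on MCF7 cells (Homo sapiens) for inhibition; on this read-out higher numbers stand for weaker inhibition and lower numbers for stronger inhibition. Compound 1 gives 750 nM in this assay, and compound 2 gives 1200 nM. Compound 2 therefore holds the highest of the two numbers, but its nearest neighbour, compound 1, lies within the usual scatter of repeated measurements, so the two values cannot be told apart. Among the compounds with values here, the two structures also differ in more than one place, so no single step between them can be read.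

Compound 3, `CCn1c(=O)/c(=C2\Sc3cc(F)ccc3N2C)s/c1=C\c1ccncc1Nc1ccccc1F`, has not yet been measured. It differs from compound 2 in one place: fluoro in place of ethyl on an aromatic carbon.

Within the data shown here, with only two measured compounds, and neither of them separated by a single change, the account has no step of its own to lean on. A small substituent swap on the fused ring is expected to move this assay little, and no step beyond the scatter is expected from compound 2 to compound 3, so a 1.2-fold lower number from compound 2 to compound 3 (0.08 log units; within the scatter) is the estimated change. Compound 3 is thus expected to give about 1000 nM, with a likely range from 400 nM to 2500 nM.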

Compound 3, half-maximal inhibitory concentration: 230 nM
Compound 3: the middle estimate sits 4.3-fold (0.64 log units) above what was measured; measured number below the stated range.
By their numbers in this assay, from the lowest: compound 3; then compounds 1 and 2 (each within the scatter of the next).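

In this assay, within the data shown here, fluoro in place of ethyl on the fused ring gives a 5.2-fold lower number from compound 2 to compound 3 (0.72 log units; beyond the scatter), the first step in this set that can be read. It shows that this aromatic carbon is not a silent position: with the rest of the molecule unchanged, a single substituent swap there moves the number beyond the scatter. The swap removes two carbon atoms and adds one fluorine atom, with no hydrogen-bond donor, hydrogen-bond acceptor or net charge on either side of the change, and no measurement shown here accounts for the fall in the number.

This one step cannot separate what losing the ethyl contributes from what gaining the fluoro contributes, and the route through compound 1 offers no help, as compound 1 differs from both other compounds in more than one place. On these data alone, whether the lower number belongs to fluoro in particular or would also appear with a methyl, a methoxy or an amine on the same carbon remains open, as does whether a longer chain there would raise the number further.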